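Chain-acid diphenylpyridazine thioethers: extending the acid chain

This account rests on a few compounds, and the source may have more. Where it says the series, first, only, none or still open, it means among the compounds named here.

The shared core carries a thioether chain on a diphenyl-substituted six-membered ring. Compound 1 `CCCCCCSc1cc(-c2ccccc2)c(-c2ccccc2)nn1` bears a hexyl chain and in an assay on microsomes from liver for inhibition of sterol O-acyltransferase 1 (Rattus norvegicus) (a lower number here means a stronger inhibitor, a higher number a weaker inhibitor), compound 1 gives 62000 nM. Compound 2 `CCCCCCCCCSc1cc(-c2ccccc2)c(-c2ccccc2)nn1` bears a nonyl chain and in this assay compound 2 gives 116000 nM; the step of a 1.9-fold higher number from compound 1 to compound 2 (0.27 log units; within the scatter) is flat. Compound 3 `O=C(O)CCCCCSc1cc(-c2ccccc2)c(-c2ccccc2)nn1` carries a carboxy group at the end of the chain. In this assay compound 3 reaches only the limit of > 300000 nM, and its place among the three is set by the limit of > 300000 nM in this assay, at which 1 of the 3 values shown sits. The steps of an at least 4.8-fold higher number from compound 1 to compound 3 (0.68 log units; beyond the scatter) and an at least 2.5-fold higher number from compound 2 to compound 3 (0.41 log units; beyond the scatter) show that putting the acid on the chain end pushes the number upward beyond the scatter in both cases.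

Compound 4 `O=C(O)CCCCCCCCSc1cc(-c2ccccc2)c(-c2ccccc2)nn1` is the next member: 3-carboxypropyl in place of carboxy on a saturated chain carbon, five bonds along the chain from a sulfur. The bearing steps are the chain extension a 1.9-fold higher number from compound 1 to compound 2 (0.27 log units; within the scatter), which changed nothing beyond the scatter, and the two acid-introducing steps an at least 4.8-fold higher number from compound 1 to compound 3 (0.68 log units; beyond the scatter) and an at least 2.5-fold higher number from compound 2 to compound 3 (0.41 log units; beyond the scatter), which were unfavourable; since compound 4 keeps the acid and only lengthens the chain, no recovery is expected and the number is expected to remain at or beyond the limit. The expected step is a step that the limit leaves unreadable from compound 3 to compound 4. For compound 4 the estimated value in this assay is 400000 nM, with a range from 150000 nM to 1500000 nM.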

Compound 4, half-maximal inhibitory concentration: > 300000 nM
Compound 4 ended at the assay's limit (the forecaster's own chance of this, stated with the estimate: 70%); the middle value is on the limit's open side.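

In this assay compound 4 gives > 300000 nM, which is a limit of the assay and not a number, so adding 3-carboxypropyl in place of carboxy, five bonds along the chain from a sulfur, brings no readable value back. Carboxy in place of methyl, eight bonds along the chain from a sulfur, gives an at least 2.5-fold higher number from compound 2 to compound 4 (0.41 log units; beyond the scatter), and 2-carboxyethyl in place of hydrogen, six bonds along the chain from a sulfur, gives an at least 4.8-fold higher number from compound 1 to compound 4 (0.68 log units; beyond the scatter), so the loss seen earlier with the acid on the shorter chain also holds with the acid on the longer chain. The steps from compound 3 to compound 4 cannot be read, and the size of the acid change cannot be compared between the two chain lengths: the same change on two cores in this assay, an at least 4.8-fold higher number (0.68 log units; beyond the scatter) from compound 1 to compound 3 and an at least 2.5-fold higher number (0.41 log units; beyond the scatter) from compound 2 to compound 4; the limit leaves it open whether they differ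

Going by these compounds, whether an amine, an amide or an ester at the chain end would return a readable value in this assay remains open. How far compound 3 and compound 4 lie past the limit, and whether they differ at all, also remains open: the limit of > 300000 nM in this assay, at which 2 of the 4 values shown sit.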